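The source may report more compounds than this note shows. Statements on the series, on what has been measured and on what is new or still open speak of the compounds shown alone.

Measured in a functional assay on C8166 cells (Homo sapiens) for cytotoxicity, read by MTT assay; on this read-out higher numbers stand for lower toxicity in this test and lower numbers for higher toxicity in this test:

- compound 1 `Cc1cccc(C(=O)Nc2cc(Cl)ccc2OCC(=O)Nc2ccc(S(N)(=O)=O)cc2C)c1`: 52900 nM
- compound 2 `Cc1ccc(C(=O)Nc2cc(Cl)ccc2OCC(=O)Nc2ccc(S(N)(=O)=O)cc2C)cc1`: 54200 nM
- compound 3 `COc1ccc(C(=O)Nc2cc(Cl)ccc2OCC(=O)Nc2ccc(S(N)(=O)=O)cc2C)cc1`: 69500 nM

Compound 2, at 54200 nM, lies within the scatter of both other compounds, so the three values form one tight group. The next compound to be tested is compound 4 `Cc1ccc(C(=O)Nc2cc(Cl)ccc2OCC(=O)Nc2ccc(S(N)(=O)=O)cc2C)c(C)c1`. It differs from compound 2 as follows: methyl in place of hydrogen on an aromatic carbon. In words, this is methyl in place of hydrogen on an aromatic carbon, turning 4-methylphenyl into 2,4-dimethylphenyl.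

For the measured compounds named here, no measured step makes this exact change. The nearest evidence comes from changes on the same ring: a 1.0-fold higher number from compound 1 to compound 2 (0.01 log units; within the scatter), a 1.3-fold higher number from compound 1 to compound 3 (0.12 log units; within the scatter) and a 1.3-fold higher number from compound 2 to compound 3 (0.11 log units; within the scatter). None of these goes beyond the scatter, although three compounds are a narrow basis and none carries a second methyl.

The expectation is therefore for no change beyond the scatter in this assay, with the range kept wide for the untested substitution. The estimated step is a 1.0-fold lower number from compound 2 to compound 4 (0.02 log units; within the scatter). Compound 4 is expected at 52000 nM, with an estimated range of 28000 nM to 95000 nM.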

Compound 4, half-maximal cytotoxic concentration: 47600 nM
Estimate against measurement, compound 4: 1.1-fold (0.04 log units) above; low and high end bracket the measured number.
By their numbers in this assay, from the lowest: compounds 4, 1, 2 and 3 (each within the scatter of the next).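

In this assay, a methyl group placed ortho to a large group, turning 4-methylphenyl into 2,4-dimethylphenyl, gives a 1.1-fold lower number from compound 2 to compound 4 (0.06 log units; within the scatter), so this ring position takes a second methyl without a step beyond the scatter. The same holds against the other two ring patterns, with a 1.1-fold lower number from compound 1 to compound 4 (0.05 log units; within the scatter) and a 1.5-fold lower number from compound 3 to compound 4 (0.16 log units; within the scatter), so the four compounds remain one tight group even with a substituent at this new position. Nothing available offers an explanation for this result.

The compounds shown leave open whether a bulkier group at this position, such as tert-butyl, or one carrying an amine or a carboxylic acid, would also stay within the scatter. They also leave open whether the picture holds once the chloro group or the sulfonamide of the shared core is replaced.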